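Hexadecyl pyridinol series: amine swap at the ring

This account rests on a few compounds, and the source may have more. Where it says the series, first, only, none or still open, it means among the compounds named here.

Measured so far:
compound 1 `CCCCCCCCCCCCCCCCc1c(C)c(N(C)C)nc(C)c1O` — 85%
compound 2 `CCCCCCCCCCCCCCCCc1nc(N2CCC2)c(C)c(C)c1O` — 81%

Working notes. In a functional assay on cells (Lymphocyte, Homo sapiens), read by trypan blue exclusion, with a stated time of 16 h, tested at 2.5 uM (a lower number here means a weaker effect, a higher number a stronger effect of the compound at the concentration tested), compound 1 gives 85% and compound 2 gives 81%; the two values lie within the scatter of each other, so compound 2 stands level with compound 1 on the numbers shown. Compound 3 `CCCCCCCCCCCCCCCCc1nc(N(C)C)c(C)c(C)c1O` has not yet been measured. It differs from compound 2 by dimethylamino in place of azetidin-1-yl on an aromatic carbon. For the measured compounds named here, no measured pair shows this change directly, so any expectation rests on the two values above. Because compound 1, which also carries dimethylamino, gives 85%, no step beyond the scatter is expected in either direction. The estimated step of a number 2 percentage points higher from compound 2 to compound 3 (within the scatter) is small. Compound 3 is estimated at 83%, between 70% and 93%.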

Compound 3, a percentage reported as activity, at one concentration (the size of the read-out at that concentration, not a potency): 83%
Beside the measured number, compound 3's estimate shows no gap at the digits printed, and the stated range covers the measured number.
By their numbers in this assay, from the lowest: compounds 2, 3 and 1 (each within the scatter of the next).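

In this assay, for the compounds shown here, the direct pair gives a number 2 percentage points higher from compound 2 to compound 3 (within the scatter), the first reading of this change at this position, para to a hydroxy group. Azetidin-1-yl and dimethylamino cannot be told apart here, so the four-membered ring is not needed to keep the read-out at this concentration. Nothing measured bears on why the two groups match. On these data alone, whether a pyrrolidine or morpholine ring at this position would hold the read-out stays open. So does the effect of a shorter alkyl chain on the shared core.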